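Swapping the Ring on Compound 2: What to Expect

This account rests on a few compounds, and the source may have more. Where it says the series, first, only, none or still open, it means among the compounds named here.

Measured so far in an ADME assay on microsomes from liver (Mus musculus) for metabolic stability, with a stated time of 10 min; a higher number here means that more of the compound is left, a lower number that less of the compound is left:
- compound 1 `CNC(=O)c1nnc(NC(=O)C2CC2)cc1Nc1cccc(-c2cnccn2)c1OC`: 1%
- compound 2 `CNC(=O)c1nnc(NC(=O)C2CC2)cc1Nc1cccc(-c2ccncn2)c1OC`: 3%

Within the data shown here, only two compounds have been measured, and compound 2 stands at 3%, level with compound 1 within the usual scatter. Very little of either compound is left at the end of the test.

The next compound is compound 3 `CNC(=O)c1nnc(NC(=O)C2CC2)cc1Nc1cccc(-c2cnc(C(C)(C)O)cn2)c1OC`. It has 5-(1-hydroxy-1-methylethyl)pyrazin-2-yl in place of pyrimidin-4-yl on an aromatic carbon.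

Among the measured compounds shown here, the one measured step, a number 2 percentage points higher from compound 1 to compound 2 (within the scatter), exchanges one ring for another and stays small. For the measured compounds named here, no measured compound carries the 1-hydroxy-1-methylethyl group, so this step is only a weak guide. In this assay a small upward move, within the scatter, is expected, shown by the estimated a number 5 percentage points higher from compound 2 to compound 3 (within the scatter). The estimate for compound 3 is 8%, with an expected range of 1% to 30%.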

Compound 3, percent of the compound remaining: 99%
The estimate for compound 3 lay 91 percentage points below the measured number; measured number outside the range, above it.
By their numbers in this assay, from the lowest: compounds 1 and 2 (each within the scatter of the next); then compound 3.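

In this assay the clearest comparison is a number 98 percentage points higher from compound 1 to compound 3 (beyond the scatter). These two compounds share the pyrazin-2-yl ring and differ only in 1-hydroxy-1-methylethyl in place of hydrogen on an aromatic carbon. The step of a number 96 percentage points higher from compound 2 to compound 3 (beyond the scatter) is of similar size although the ring changes as well, while the exchange of one unsubstituted ring for the other gave only a number 2 percentage points higher from compound 1 to compound 2 (within the scatter), so among these compounds the large rise comes with the added group and not with the choice of ring. Nothing available here explains why the added group goes with so large a rise.

Going by these compounds, it remains open whether the hydroxyl matters or whether a tert-butyl group, an amine or a carboxylic acid at the same place would do as well. The compounds shown also leave open how 1-hydroxy-1-methylethyl would behave on the pyrimidin-4-yl ring.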